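Exchanging the Ring on the Sulfonyl Sulfur

The compounds below may be only part of what the source reports. "The series", "measured", "known", "first", "only" and "open" are said of these compounds alone.

Compound 1 `CC(C)(C)c1ccc(CN(Cc2cccc(CCC(=O)O)c2)S(=O)(=O)c2ccccc2)cc1`: > 3200 nM
Compound 2 `CC(C)(C)c1ccc(CN(Cc2cccc(CCC(=O)O)c2)S(=O)(=O)c2nccs2)cc1`: > 3200 nM

Both compounds share one core and differ only in the ring carried by the sulfonyl sulfur. In an assay on HEK293 cells for inhibition of prostaglandin E2 receptor EP4 subtype (Rattus norvegicus) (on this read-out higher numbers stand for weaker inhibition and lower numbers for stronger inhibition), compound 1 gives > 3200 nM, which is a limit of the assay and not a number. In this assay compound 2 gives > 3200 nM, again a limit. The step that the two limits leave unreadable from compound 1 to compound 2 cannot be sized because of the limit of > 3200 nM in this assay, at which 2 of the 2 values shown sit. Among the measured compounds shown here, compound 2 therefore stands at the limit, and the one other value shown also stands there.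

Compound 3 `CC(C)(C)c1ccc(CN(Cc2cccc(CCC(=O)O)c2)S(=O)(=O)c2ccc(Cl)cc2)cc1` is not yet measured. It differs from compound 2 by 4-chlorophenyl in place of 1,3-thiazol-2-yl on a sulfonyl sulfur. For the measured compounds named here, the only measured step concerns the same position but gives no readable size, so there is no measured trend to build on. Compound 3 is expected to give about 5000 nM in this assay, most likely reported again as a limit, within 1500 nM to 30000 nM. The expected step is a step that the limit leaves unreadable from compound 2 to compound 3, none beyond the scatter.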

Compound 3, half-maximal inhibitory concentration: > 3200 nM
Compound 3: only a limit was reported; the forecaster's own chance of this, stated with the estimate: 75%; the middle value lies beyond the limit too.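

In this assay compound 3 gives > 3200 nM, again a limit and not a number. Among the compounds shown here, no step among compound 1, compound 2 and compound 3 can be read, because all three stand at the same limit: the limit of > 3200 nM in this assay, at which 3 of the 3 values shown sit. As far as these compounds go, how strongly each compound actually inhibits, and how much the ring on the sulfonyl sulfur matters, stays open.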